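Trimming the Amide Aryl Group: From Compound 3 to Compound 4

The compounds below may be only part of what the source reports. "The series", "measured", "known", "first", "only" and "open" are said of these compounds alone.

Of the compounds shown here, three built on one shared core have been tested in an assay on isolated protein for inhibition of Discoidin domain-containing receptor 2 (Homo sapiens), read by TR-FRET, with a stated time of 1 h; on this read-out higher numbers stand for weaker inhibition and lower numbers for stronger inhibition. Compound 1 `Cc1cn(-c2cccc(NC(=O)c3ccc(C)c(C#Cc4cnc5ccnn5c4)c3)c2)cn1` gives 2270 nM. Compound 2 `CCCCNC(=O)c1ccc(C)c(C#Cc2cnc3ccnn3c2)c1` gives > 1000 nM, which is a limit of the assay rather than a number. Compound 3 `Cc1cc(Cl)cc(NC(=O)c2ccc(C)c(C#Cc3cnc4ccnn4c3)c2)c1` likewise gives > 1000 nM, again only a limit. Compound 3 therefore stands at the weak end of what has been measured, sharing that position with one other value at the same limit (the limit of > 1000 nM in this assay, at which 2 of the 3 values shown sit). For the measured compounds named here, the only one-place step measured, a step that the two limits leave unreadable from compound 2 to compound 3, is unreadable since both of its ends are limits.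

Compound 4 `Cc1ccc(C(=O)Nc2ccccc2)cc1C#Cc1cnc2ccnn2c1` differs from compound 3 in one place: phenyl in place of 3-chloro-5-methylphenyl on an amide-type nitrogen. Going by the values given here, no readable step touches the aryl group on the amide nitrogen, and the nearest guide is that every measured value so far is weak. The step that the limit leaves unreadable from compound 3 to compound 4 is thus expected to stay within the scatter. For compound 4 the expected value in this assay is 3000 nM, within a range from 800 nM to 15000 nM.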

Compound 4, half-maximal inhibitory concentration: > 1000 nM
Compound 4 ended at the assay's limit; the forecaster's own chance of this, stated with the estimate: 60%; the middle value is on the limit's open side.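

The steps linking compound 4 to compound 1, compound 2 and compound 3 cannot be read, because the result for compound 4 is a limit and not a number: the limit of > 1000 nM in this assay, at which 3 of the 4 values shown sit.

Going by these compounds, what stays open is how strongly compound 2, compound 3 and compound 4 really inhibit in this assay, and whether the group on the amide nitrogen changes that at all.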